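This account rests on a few compounds, and the source may have more. Where it says the series, first, only, none or still open, it means among the compounds named here.

In a functional assay on HepG2 cells (Homo sapiens) for cytotoxicity, read by MTT assay, with a stated time of 48 h (a lower number here means a stronger inhibitor, a higher number a weaker inhibitor), compound 1, with the structure `CSc1nnc(C)n1N1C(=O)c2ccccc2C1=O`, gives only a limit of the assay, > 200000 nM. Compound 2, with the structure `CCCc1nnc(SCC(=O)c2ccc(Cl)cc2)n1N1C(=O)c2ccccc2C1=O`, likewise reaches only a limit in this assay, > 200000 nM. Both results therefore sit at the same boundary, as noted in the limit of > 200000 nM in this assay, at which 2 of the 2 values shown sit, so compound 2 stands nowhere distinct on the numbers shown. Compound 3, with the structure `CCCc1nnc(SC)n1N1C(=O)c2ccccc2C1=O`, differs from compound 2 by hydrogen in place of (4-chlorophenyl)carbonyl on a saturated chain carbon bound to a sulfur. Going by the values given here, with no measured step to lean on, the change from compound 2 to compound 3 is expected to give no step beyond the scatter, a step that the limit leaves unreadable from compound 2 to compound 3. Compound 3 is estimated at 300000 nM, within 100000 nM to 1000000 nM.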

Compound 3, half-maximal inhibitory concentration: > 200000 nM
Compound 3 gave a limit, no number; the forecaster's own chance of this, stated with the estimate: 85%; the middle value lies beyond the limit too.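

Compound 3 also gives only a limit in this assay, > 200000 nM. The steps to compound 3 from compound 1 and compound 2 cannot be read: the limit of > 200000 nM in this assay, at which 3 of the 3 values shown sit.

The compounds shown leave open whether any of them has a measurable effect on these cells, and whether changing a group on the shared core alters it.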